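This account rests on a few compounds, and the source may have more. Where it says the series, first, only, none or still open, it means among the compounds named here.

Compound 1 `O=C(Nc1ccccc1)c1cnc(NCc2c(F)ccc3c2CCO3)n2cnnc12` sits at the top of the three numbers in a physicochemical assay for lipophilicity, using the shake flask method, in phosphate buffer, measured as octanol-water partition, with a stated time of 30 min, at pH 7.4 (on this read-out lower numbers stand for lower lipophilicity and higher numbers for higher lipophilicity), with compound 1 giving 4.1. Compound 2 `CNC(=O)c1cc(-c2cnc(NCc3c(F)ccc4c3CCO4)c3cn[nH]c(=O)c23)n(C)n1` gives 2.1 and compound 3 `CNC(=O)c1ccc(-c2cnc(NCc3c(F)ccc4c3CCO4)c3cn[nH]c(=O)c23)c(C)n1` gives 2.9; compound 3 is the nearer of the two to compound 1, compound 2 the further. Among the compounds with values here, the one measured step, a number 0.80 log units higher from compound 2 to compound 3 (beyond the scatter), swaps one aryl group for another on a different core and does not touch the position changed here, so it offers no direct guide. Compound 4 `O=C1CCCN1c1cnc(NCc2c(F)ccc3c2CCO3)n2cnnc12` differs from compound 1 by 2-oxopyrrolidin-1-yl in place of phenylcarbamoyl on an aromatic carbon. Within the data shown here, no measured pair in the set isolates this exchange, so the expectation rests on the value of compound 1 and on the counted change alone: fewer heavy atoms, loss of the aromatic carbon ring and of the one hydrogen-bond donor. In this assay a step of a number 1.30 log units lower from compound 1 to compound 4 (beyond the scatter) is expected, a drop beyond the scatter. Compound 4 is therefore estimated at 2.8, in the range 2.2 to 3.4.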

Compound 4, distribution coefficient: 1.3
Beside the measured number, compound 4's estimate is 1.50 log units above it; the whole stated range lies above it.
By their numbers in this assay, from the lowest: compound 4; then compound 2; then compound 3; then compound 1.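

In this assay, the position para to a large group on the core of compound 1 proves highly sensitive to the substituent: 2-oxopyrrolidin-1-yl in place of phenylcarbamoyl gives a number 2.80 log units lower from compound 1 to compound 4 (beyond the scatter). This single exchange changes several counted features together, replacing the six-membered aromatic ring of carbon only with a five-membered non-aromatic ring, removing the amide hydrogen and reducing the heavy-atom count. No measurement shown accounts for the size of this step.

Which of these features carries the step remains open, as the one pair cannot separate them. Cyclohexylcarbamoyl at this position would keep the amide hydrogen without the aromatic ring, while N-methyl-N-phenylcarbamoyl would keep the aromatic ring without the amide hydrogen.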